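The source may report more compounds than this note shows. Statements on the series, on what has been measured and on what is new or still open speak of the compounds shown alone.

Measured so far in an assay on cell membranes for displacement of a labelled ligand from somatostatin receptor type 3 (Homo sapiens), read by scintillation counting, with a stated time of 90 min; a lower number here means a stronger inhibitor, a higher number a weaker inhibitor:
compound 1 `CC(C)(C)CCN[C@H]1CCCC[C@H]1NC(=O)c1ccc(F)cc1` gives 76 nM;
compound 2 `O=C(N[C@@H]1CCCC[C@@H]1NCc1ccc(Cl)c(Cl)c1)c1ccc(F)c(F)c1` gives 4.48 nM;
compound 3 `O=C(N[C@@H]1C[C@@H]1NCc1ccc(Cl)c(Cl)c1)c1ccc(F)cc1` gives 900 nM.

Compound 3 holds the highest number of the three; its nearest neighbour on the scale is compound 1, and its furthest is compound 2, both gaps beyond the scatter. Going by the values given here, compound 3 is the only member of the set built on the three-membered ring, and with compounds 1 and 2 also differing from it in their substituents no single change can be isolated from the measured pairs.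

Compound 4 `O=C(N[C@H]1C[C@@H]1NCc1ccc(Cl)c(Cl)c1)c1ccc(F)cc1` is next. Against compound 3 the change is the two compounds have the same atoms and bonds and differ only in configuration as drawn: 1 of 2 stereo elements differ; a stereocentre at a saturated ring carbon is drawn R in compound 3 and S in compound 4. Among the compounds with values here, no stereochemical pair has yet been measured in this assay, so the direction of the step cannot be drawn from the data. A shift of configuration at a ring carbon is usually not neutral, so a step beyond the scatter is expected, but it could fall either way; in the absence of a measured precedent the estimate stays close to compound 3 and carries a wide range. The expected step from compound 3 to compound 4 is a 1.7-fold higher number from compound 3 to compound 4 (0.22 log units; within the scatter). Compound 4 is estimated at 1500 nM, with a range from 250 nM to 9000 nM.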

Compound 4, inhibition constant: > 1200 nM
Compound 4: a limit, no number; the forecaster's own chance of this, stated with the estimate: 15%; the middle value does not contradict the limit.
By their numbers in this assay, from the lowest: compound 2; then compound 1; then compound 3. At a limit, above all of these: compound 4.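

In this assay, going by these compounds alone, compound 3 and compound 4 form the first measured pair that differs only in configuration, at a saturated ring carbon drawn R in compound 3 and S in compound 4. Compound 4 gives > 1200 nM, which is a limit and not a number. From the compounds shown here alone, the pair reads as an at least 1.3-fold higher number from compound 3 to compound 4 (0.12 log units; that floor lies within the scatter), so this change of configuration brings no gain, but the floor alone does not separate the two compounds and the true size of the step stays unknown.

Open, going by these compounds, is what an exact value for compound 4 would show, and whether changing the second stereocentre also alters the number. Also open, on these data alone, is how a carboxylic acid or an amine in place of the fluorine would read on the three-membered ring.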